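The source may report more compounds than this note shows. Statements on the series, on what has been measured and on what is new or still open speak of the compounds shown alone.

This account follows the step from compound 3 to compound 4 in a physicochemical assay for solubility; on this read-out higher numbers stand for higher solubility and lower numbers for lower solubility. Compound 3, with structure `CNC(=O)c1cc(C(=O)NC2CC2)cn(Cc2cccc3cc[nH]c23)c1=O`, gives >= 144 ug/mL in this assay, and that figure is a limit of the assay rather than a number. Two further compounds sharing the same core have been measured in this assay. Compound 1, `CNC(=O)c1cc(C(=O)NC2CCC2)cn(Cc2cccc(NC)c2)c1=O`, gives >= 155 ug/mL in this assay, which is likewise a limit. Compound 2, `CNC(=O)c1cc(C(=O)NCCCC2CNCCO2)cn(Cc2ccccc2)c1=O`, gives >= 194 ug/mL in this assay, again a limit. Within the data shown here, compound 3 therefore stands at one of three limits, namely (the limit of >= 144 ug/mL in this assay, at which 1 of the 3 values shown sits), beside the limit of >= 155 ug/mL in this assay, at which 1 of the 3 values shown sits, and (the limit of >= 194 ug/mL in this assay, at which 1 of the 3 values shown sits), and no step between measured compounds can be read from these values.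

Compound 4, `CNC(=O)c1cc(C(=O)NC2CC2)cn(Cc2ccccc2F)c1=O`, has not yet been measured in this assay. It differs from compound 3 in one place: 2-fluorophenyl in place of 1H-indol-7-yl on a saturated chain carbon bound to an aromatic nitrogen. Among the measured compounds shown here, with no measured step available, the data give no size or direction for the move from compound 3 to compound 4. All three measured values are limits, so the expected step is none beyond the scatter, with compound 4 expected to reach a limit as well. The step that this expectation means is a step that the limit leaves unreadable from compound 3 to compound 4. Compound 4 is estimated at 150 ug/mL in this assay, with a range from 60 ug/mL to 300 ug/mL.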

Compound 4, solubility: >= 145 ug/mL
Compound 4: a limit, no number; the forecaster's own chance of this, stated with the estimate: 60%; the middle value lies beyond the limit too.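

In this assay, compound 3 and compound 4 both stand at limits of the assay rather than at numbers, so no step can be read between them. The compounds shown leave open whether 2-fluorophenyl in place of 1H-indol-7-yl on a saturated chain carbon bound to an aromatic nitrogen changes this read-out at all, and by how much.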